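The source may hold more compounds than are shown below. What is called first, only, known or untested is meant among the compounds shown, and "the series" means these compounds.

Measured in a physicochemical assay, read by spectrophotometry; on this read-out higher numbers stand for weaker inhibition and lower numbers for stronger inhibition:
- compound 1 `CN(C)c1ccc(/C=C/C(=O)/C(CNc2ccccc2)=C(O)/C=C/c2ccc(N(C)C)cc2)cc1`: 79.1 ug/mL
- compound 2 `CN(C)c1ccc(/C=C/C(=O)/C(CNc2cccc(C(F)(F)F)c2)=C(O)/C=C/c2ccc(N(C)C)cc2)cc1`: 81.7 ug/mL

Within the data shown here, on this assay, compound 2 cannot be told apart from the only other measured compound, and the data show a 1.0-fold higher number from compound 1 to compound 2 (0.01 log units; within the scatter). The account now turns to compound 3 `COc1ccccc1NC/C(C(=O)/C=C/c1ccc(N(C)C)cc1)=C(O)\C=C\c1ccc(N(C)C)cc1`, which carries 2-methoxyphenyl in place of 3-(trifluoromethyl)phenyl on an amine nitrogen.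

Among the measured compounds shown here, only one measured step bears on this change. It is trifluoromethyl in place of hydrogen on an aromatic carbon, and its size is a 1.0-fold higher number from compound 1 to compound 2 (0.01 log units; within the scatter). For the measured compounds named here, that step stayed within the scatter, but it is a single observation, and no measured compound carries 2-methoxyphenyl. It offers no ground for expecting a shift in either direction, though it cannot exclude one. The expected outcome is therefore no step beyond the scatter, and the estimate is a 1.0-fold lower number from compound 2 to compound 3 (0.01 log units; within the scatter). The range is kept wide to reflect how little evidence there is. For compound 3 the expected value is 80 ug/mL, with an estimated range from 45 ug/mL to 140 ug/mL.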

Compound 3, half-maximal inhibitory concentration: 76.3 ug/mL
The estimate for compound 3 lay 1.0-fold (0.02 log units) above the measured number; measured number inside the range.
By their numbers in this assay, from the lowest: compounds 3, 1 and 2 (each within the scatter of the next).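

The new compound adds a second substituent on the aromatic ring to the single one seen before: in this assay, the change to 2-methoxyphenyl on the amine nitrogen gives (a 1.1-fold lower number from compound 2 to compound 3 (0.03 log units; within the scatter)), and methoxy in place of hydrogen on an aromatic carbon gives (a 1.0-fold lower number from compound 1 to compound 3 (0.02 log units; within the scatter)). Trifluoromethyl alone had left the read-out within the scatter, and now methoxy, which brings an oxygen and a hydrogen-bond acceptor to this group, does so too, leaving compounds 1, 2 and 3 indistinguishable on this read-out. No measurement shown here offers an explanation for this result.

The step between compound 2 and compound 3 changes both the substituent and its printed ring position, so 3-methoxyphenyl or 2-(trifluoromethyl)phenyl would be needed to tell those two changes apart. On these data alone, it also remains open whether any group on this amine nitrogen can move the number beyond the scatter, such as a benzyl or cyclohexyl group in place of the aromatic ring, or a carboxylic acid on that ring.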